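The source may hold more compounds than are shown below. What is called first, only, known or untested is meant among the compounds shown, and "the series" means these compounds.

Working notes on the series: in a functional assay on A549 cells (Homo sapiens) for cytotoxicity, read by sulforhodamine B assay, with a stated time of 48 h (on this read-out higher numbers stand for weaker inhibition and lower numbers for stronger inhibition), compound 1 `COc1ccc(/C=C/C(=O)c2cccc(-c3ccc(F)cc3)c2)cc1` gives 11200 nM and compound 2 `O=C(/C=C/c1ccc(Br)cc1)c1cccc(-c2cccc(F)c2)c1` gives 19800 nM. These two values lie within the usual scatter of each other, so compound 2 stands level with compound 1. Compound 3 `O=C(/C=C/c1ccc(Cl)cc1)c1cccc(-c2cccc(F)c2)c1` differs from compound 2 by chloro in place of bromo on an aromatic carbon, para to a large group. Within the data shown here, no measured pair shows this change, and no shift beyond the scatter is expected in this assay, in either direction. The estimated step is a 1.2-fold lower number from compound 2 to compound 3 (0.07 log units; within the scatter). The expected value for compound 3 is 17000 nM, with an estimated range of 8000 nM to 35000 nM.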

Compound 3, half-maximal inhibitory concentration: 15400 nM
Compound 3: middle estimate off by 1.1-fold (0.04 log units), on the high side, and the stated range covers the measured number.
By their numbers in this assay, from the lowest: compounds 1, 3 and 2 (each within the scatter of the next).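

In this assay, the change from 4-bromophenyl to 4-chlorophenyl gives a 1.3-fold lower number from compound 2 to compound 3 (0.11 log units; within the scatter). Among these compounds, this is the first step that differs in one place, and it shows that exchanging one halogen for the other on this aromatic carbon, para to a large group, leaves the number within the scatter. No measured evidence bears on this result.

From the compounds shown here alone, whether an amine or a carboxylic acid at this position would shift the number in this assay remains open. So does the outcome of changes elsewhere on the shared core.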